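Bromo to Methyl on the Phenoxy Ring of Compound 1

The source may report more compounds than this note shows. Statements on the series, on what has been measured and on what is new or still open speak of the compounds shown alone.

Compound 1 `O=c1c2ccccc2nc(-c2ccccc2)n1/N=C/c1ccc(Oc2ccc(Br)cc2)cc1`: 6.39
Compound 2 `CCCc1nc2ccccc2c(=O)n1/N=C/c1ccc(Oc2ccc(F)cc2)cc1`: 5.22
Compound 3 `CCCc1nc2ccccc2c(=O)n1/N=C/c1ccc(Oc2ccc(Br)cc2)cc1`: 5.88

In a physicochemical assay for lipophilicity, in phosphate buffer, measured as octanol-water partition (a lower number here means a more polar compound, a higher number a more lipophilic compound), compound 1 stands highest of the three; its nearest neighbour is compound 3, and compound 2 is furthest off. Compound 4 `Cc1ccc(Oc2ccc(/C=N/n3c(-c4ccccc4)nc4ccccc4c3=O)cc2)cc1` differs from compound 1 by methyl in place of bromo on an aromatic carbon. Neither measured step matches this exchange exactly. The halogen swap a number 0.66 log units higher from compound 2 to compound 3 (beyond the scatter) shows that a change on this ring moves the read-out modestly, while a number 0.51 log units lower from compound 1 to compound 3 (beyond the scatter) concerns the other end of the core. Methyl is usually somewhat less lipophilic than bromo, so a modest downward step is expected. Compound 4 is therefore estimated at 6.09, with a range of 5.7 to 6.4, meaning an expected step of a number 0.30 log units lower from compound 1 to compound 4 (within the scatter).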

Compound 4, partition coefficient: 6.29
Estimate against measurement, compound 4: 0.20 log units below; measured number inside the range.
By their numbers in this assay, from the lowest: compound 2; then compound 3; then compounds 4 and 1 (each within the scatter of the next).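

In this assay, going from 4-bromophenoxy to 4-methylphenoxy gives a number 0.10 log units lower from compound 1 to compound 4 (within the scatter) and so leaves the two compounds indistinguishable. The earlier halogen exchange on this ring gave a number 0.66 log units higher from compound 2 to compound 3 (beyond the scatter) and the new result shows that replacing one heavy atom at this position need not move the read-out. Nothing available explains this result.

Going by these compounds, it remains open whether methyl in place of bromo would behave the same way with propyl on the core, as in compound 3. On these data alone, it is also open how an amine or a carboxylic acid at this position would read.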